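The compounds below may be only part of what the source reports. "The series", "measured", "known", "first", "only" and "open" are said of these compounds alone.

Compound 3 `NCc1cc(Oc2cccc(C(=O)NCCn3cnnn3)c2)nc(C(F)(F)F)c1` gives 1990 nM in an ADME assay on the whole organism (plasma, Mus musculus) for pharmacokinetics, read by LC-MS, at a dose of 30 mg/kg by the oral route; on this read-out higher numbers stand for higher exposure at the dose given and lower numbers for lower exposure. Of the two numbers reported here it stands at the top, yet only within the scatter: compound 1 `NCc1cc(Oc2cccc(C(=O)NCCS(N)(=O)=O)c2)nc(C(F)(F)F)c1` gives 1040 nM in this assay, and the step of a 1.9-fold higher number from compound 1 to compound 3 (0.28 log units; within the scatter) is within the usual spread of repeats. For compound 2 `NCc1cc(Oc2cccc(Oc3ccccc3)c2)nc(C(F)(F)F)c1` the entry in this assay reads "not determined" (no result reported), so no number is reported for it. Compound 4 `NCc1cc(Oc2cccc(C(=O)NC[C@@H](O)CO)c2)nc(C(F)(F)F)c1` differs from compound 3 by 1,2-dihydroxyethyl in place of (1H-tetrazol-1-yl)methyl on a saturated chain carbon bound to an amide-type nitrogen. For the measured compounds named here, the only measured step at this part of the chain, a 1.9-fold higher number from compound 1 to compound 3 (0.28 log units; within the scatter), stayed within the scatter, so exchanging one chain group for another has so far moved little; no measured pair covers a ring giving way to an open chain, so the expectation rests near compound 3. Compound 4 is therefore expected to give about 1500 nM, between 500 nM and 4500 nM, an expected step of a 1.3-fold lower number from compound 3 to compound 4 (0.12 log units; within the scatter).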

Compound 4, maximal plasma concentration: 2770 nM
Estimate against measurement, compound 4: 1.8-fold (0.27 log units) below; measured number inside the range.
By their numbers in this assay, from the lowest: compounds 1, 3 and 4 (each within the scatter of the next, the first and the last beyond it).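

A ring is not required on this saturated chain carbon bound to an amide-type nitrogen for exposure of this size, since the open 1,2-dihydroxyethyl group gives a 1.4-fold higher number from compound 3 to compound 4 (0.14 log units; within the scatter). Set against sulfamoylmethyl, the same group gives the first step in this series to clear the scatter, a 2.7-fold higher number from compound 1 to compound 4 (0.43 log units; beyond the scatter), although it is modest. Nothing measured here gives a reason for these numbers. As far as these compounds go, whether a simple amine, a carboxylic acid or a longer chain at this place would keep such exposure stays open, as does the role of the defined stereocentre in 1,2-dihydroxyethyl.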